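A few compounds are considered here, and "the series" means these few. Any claim that something is new, unique, unknown or untested is made for them only; others in the source may bear on it.

In an assay on HEK293 cells for positive allosteric modulation of metabotropic glutamate receptor 2 (Rattus norvegicus), read by thallium flux, with a stated time of 2.5 min (a lower number here means that less compound is needed, a higher number that more compound is needed for the effect), compound 1 `Cc1c(OCCCCOc2ccc(C(=O)O)cc2Cl)ccc(C(=O)CC2CCCC2)c1O` gives 237 nM. Compound 3 `Cc1c(OCCCCOc2ccc(F)c(C(=O)O)c2)ccc(C(=O)CC(C)(C)C)c1O` gives 208 nM in this assay, and compound 2 `Cc1c(OCCCCOc2ccc(C(=O)C(C)C)c(O)c2C)cccc1C(=O)O` gives 149 nM; the three numbers lie within the usual scatter of one another, so compound 1 is not set apart from either of them. Compound 4 `Cc1ccc(C(=O)O)cc1OCCCCOc1ccc(C(=O)CC2CCCC2)c(O)c1C` has not yet been measured. It differs from compound 1 in one place: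
5-carboxy-2-methylphenyl in place of 4-carboxy-2-chlorophenyl on an oxygen on a saturated carbon
Among the measured compounds shown here, no measured pair shows this change on its own, and the three measured compounds, which differ from one another in several places at once, give no direction for it. The change is expected to move the number by no more than the scatter, a 1.2-fold lower number from compound 1 to compound 4 (0.10 log units; within the scatter). Compound 4 is estimated at 190 nM, with a range from 80 nM to 450 nM.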

Compound 4, half-maximal effective concentration: 1290 nM
Compound 4: the middle estimate sits 6.8-fold (0.83 log units) below what was measured; measured number above the stated range.
By their numbers in this assay, from the lowest: compounds 2, 3 and 1 (each within the scatter of the next); then compound 4.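

In this assay the aryl group on an oxygen on a saturated carbon proves able to shift the number on its own: 5-carboxy-2-methylphenyl in place of 4-carboxy-2-chlorophenyl gives a 5.4-fold higher number from compound 1 to compound 4 (0.74 log units; beyond the scatter) on an otherwise unchanged core. The earlier compounds shown here, which differ in several places at once, could not show this. Nothing measured here accounts for the step.

The change swaps the chlorine for a methyl and alters the carboxy placement together, and the compounds shown do not separate the two. From the compounds shown here alone, how a primary amide would read in place of the carboxy group also stays open.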